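This account rests on a few compounds, and the source may have more. Where it says the series, first, only, none or still open, it means among the compounds named here.

Measured compounds:
compound 1 `C[C@H](c1ccc(-c2cc(Cl)ccc2-c2nc(=O)o[nH]2)cc1)N(CC1CC1)c1nc2c(C(=O)O)cccc2o1`, in an ADME assay on the whole organism (plasma, Macaca fascicularis) for protein binding, read by LC-MS, using equilibrium dialysis and cassette dosing, with a stated time of 24 h, at a dose of 1 mg/kg by the oral route (on this read-out lower numbers stand for a smaller free fraction and higher numbers for a larger free fraction), compound 1 gives 0.000108
compound 2 `CCCCN(c1nc2c(C(=O)O)cccc2o1)[C@H](C)c1ccc(-c2cc(F)ccc2-c2nc(=O)o[nH]2)cc1`, in this assay compound 2 gives 0.0000736

Compound 2 gives the smaller of the two numbers, but the gap to compound 1 lies within the usual scatter of this assay, so the two values are read as equivalent. Both carry the shared core with a carboxylic acid and a chiral benzylic amine; they differ in the halogen on the biaryl and in the chain on the nitrogen, and neither difference is a single counted step here.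

Compound 3 `C[C@H](c1ccc(-c2cc(F)ccc2-c2nc(=O)o[nH]2)cc1)N(CC1CC1)c1nc2c(C(=O)O)cccc2o1` is not yet measured. Against compound 2 the change is cyclopropyl in place of propyl on a saturated chain carbon bound to a nitrogen on an aromatic ring. Among the measured compounds shown here, no measured pair isolates this change, so the expectation rests on the two values alone, and the step from compound 2 to compound 3 is expected to be small, a 1.2-fold higher number from compound 2 to compound 3 (0.09 log units; within the scatter), in no direction beyond the scatter. Compound 3 is therefore expected to give 0.00009 in this assay, within the range 0.00004 to 0.0002.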

Compound 3, unbound fraction: 0.0000977
Compound 3: middle estimate off by 1.1-fold (0.04 log units), on the low side; measured number inside the range.
By their numbers in this assay, from the lowest: compounds 2, 3 and 1 (each within the scatter of the next).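

Compound 3 links compound 1 and compound 2 through two changes that can now be read singly. Cyclopropyl in place of propyl on a saturated chain carbon bound to a nitrogen on an aromatic ring gives a 1.3-fold higher number from compound 2 to compound 3 (0.12 log units; within the scatter) in this assay, and fluoro in place of chloro on an aromatic carbon gives a 1.1-fold lower number from compound 1 to compound 3 (0.04 log units; within the scatter) on the same read-out, so neither change separates the compounds of its pair, and at this position the cyclopropyl and propyl forms of the chain read alike. No measurement at hand bears on the reason for this result.

Still open, from the compounds shown here alone, is whether a chain carrying an amine or a hydroxyl group at this position would move the unbound fraction beyond the scatter. The same holds for a nitrile or a trifluoromethyl group in place of the halogen on the aromatic carbon.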